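Four spiro compounds, three at the assay limit

The source may report more compounds than this note shows. Statements on the series, on what has been measured and on what is new or still open speak of the compounds shown alone.

Compound 1 `CCOc1ccccc1-n1nncc1CN1C(=O)C2(C(C#N)=C(N)Oc3c2c2nc4ccccc4nc2c2ccccc32)c2ccccc21` carries a 2-ethoxyphenyl on an aromatic nitrogen. In a functional assay on MCF7 cells (Homo sapiens) for antiproliferative activity, read by MTT assay, with a stated time of 48 h (a higher number here means a weaker inhibitor, a lower number a stronger inhibitor), compound 1 gives > 50000 nM, which is a limit of the assay and not a number. Compound 2 `N#CC1=C(N)Oc2c(c3nc4ccccc4nc3c3ccccc23)C12C(=O)N(Cc1cnnn1-c1ccc([N+](=O)[O-])cc1)c1ccccc12` is its 4-nitrophenyl counterpart, the change being (4-nitrophenyl in place of 2-ethoxyphenyl on an aromatic nitrogen). In this assay compound 2 gives > 50000 nM, again a limit. The step that the two limits leave unreadable from compound 1 to compound 2 is thus unreadable. Compound 3 `CCOc1ccccc1-n1nncc1CN1C(=O)C2(C(C#N)=C(N)Oc3c(N)cc4nc5ccccc5nc4c32)c2ccccc21` carries the 2-ethoxyphenyl on a core that differs from that of compound 1; the difference between the two cores is not broken down here. In this assay compound 3 gives > 50000 nM, a limit as well. Compound 4 `N#CC1=C(N)Oc2c(N)cc3nc4ccccc4nc3c2C12C(=O)N(Cc1cnnn1-c1ccc([N+](=O)[O-])cc1)c1ccccc12`, not yet measured, stands to compound 3 as compound 2 stands to compound 1: 4-nitrophenyl in place of 2-ethoxyphenyl on an aromatic nitrogen, the same change at the same place. Because the limit of > 50000 nM in this assay, at which 3 of the 3 values shown sit, holds for every value shown, nothing fixes the size of this change. The expected step that the limit leaves unreadable from compound 3 to compound 4 rests only on the unreadable step that the two limits leave unreadable from compound 1 to compound 2. Compound 4 is expected to give 70000 nM in this assay, most likely again only a limit, within a range from 30000 nM to 250000 nM.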

Compound 4, half-maximal inhibitory concentration: > 50000 nM
Compound 4 was reported as a limit (the forecaster's own chance of this, stated with the estimate: 90%); the middle value does not contradict the limit.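

In this assay compound 4 gives > 50000 nM, a limit of the assay and not a number. No step can be read from compound 3 to compound 4, because the result adds only another limit: the limit of > 50000 nM in this assay, at which 4 of the 4 values shown sit.

The compounds shown leave open how large the change from 2-ethoxyphenyl to 4-nitrophenyl is on either core, and how the two cores compare.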